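A Dimethylphenyl Group Replaces 4-Bromophenyl on the Sulfonamide

The source may hold more compounds than are shown below. What is called first, only, known or untested is meant among the compounds shown, and "the series" means these compounds.

In a functional assay on M21 cells (Homo sapiens) for antiproliferative activity, read by sulforhodamine B assay, with a stated time of 48 h (a higher number here means a weaker inhibitor, a lower number a stronger inhibitor), compound 1 (`O=C1NCCN1c1ccc(S(=O)(=O)Nc2ccc(Cl)cc2)cc1`) gives 90 nM and compound 2 (`O=C1NCCN1c1ccc(S(=O)(=O)Nc2ccc(Br)cc2)cc1`) gives 130 nM and so stands within the scatter of compound 1. Compound 3 (`Cc1cccc(NS(=O)(=O)c2ccc(N3CCNC3=O)cc2)c1C`) carries 2,3-dimethylphenyl in place of 4-bromophenyl on a sulfonamide nitrogen. Among the measured compounds shown here, the only measured step (a 1.4-fold higher number from compound 1 to compound 2 (0.16 log units; within the scatter)) exchanges one halogen for another, lies within the scatter and covers far less than this change. No step beyond the scatter is firmly expected, so the estimated step (a 1.5-fold higher number from compound 2 to compound 3 (0.19 log units; within the scatter)) stays small and uncertain. In this assay compound 3 is therefore estimated at 200 nM (range 50 nM to 800 nM).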

Compound 3, half-maximal inhibitory concentration: 110 nM
The estimate for compound 3 lay 1.8-fold (0.26 log units) above the measured number; the measured number falls inside the stated range.
By their numbers in this assay, from the lowest: compounds 1, 3 and 2 (each within the scatter of the next).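

In this assay, the step to 2,3-dimethylphenyl on the sulfonamide nitrogen is a 1.2-fold lower number from compound 2 to compound 3 (0.07 log units; within the scatter), and measured against the chloro compound it is a 1.2-fold higher number from compound 1 to compound 3 (0.09 log units; within the scatter). The earlier pair showed only one halogen exchanged for another, whereas this result shows that a phenyl group with methyl substituents and no halogen also stays within the scatter at this position. No available evidence bears on this result.

As far as these compounds go, it remains open whether a carboxylic acid or an amine on this phenyl group would also stay within the scatter. From the compounds shown here alone, whether the same holds for a longer chain at this position also remains open.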